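This account rests on a few compounds, and the source may have more. Where it says the series, first, only, none or still open, it means among the compounds named here.

Measured in a functional assay on HL-60 cells (Homo sapiens) for antiproliferative activity; on this read-out higher numbers stand for weaker inhibition of growth and lower numbers for stronger inhibition of growth:
compound 1, `CCCCCOCCCCCCC/C=C1\CC(CO)(COC(=O)C(C)(C)C)OC1=O`: 2.96 ug/mL
compound 2, `COCCCCCCCCCCCCCCC/C=C1/CC(CO)(COC(=O)C(C)(C)C)OC1=O`: 3.97 ug/mL
compound 3, `CCCCCCCCC(O)CCCCCC/C=C1\CC(CO)(COC(=O)C(C)(C)C)OC1=O`: > 10 ug/mL, which is a limit of the assay and not a number

Compound 1 has the lowest of the two numbers shown; compound 2 is only a little higher and within the scatter, so no order between the two can be claimed. Compound 3 sits at the limit of > 10 ug/mL in this assay, at which 1 of the 3 values shown sits. Compound 4, `CC(=O)NCCCCCCCCCCCCCCC/C=C1\CC(CO)(COC(=O)C(C)(C)C)OC1=O`, has not yet been measured. Its change from compound 1 is 8-acetamidooctyl in place of pentyloxy on a saturated chain carbon, seven bonds along the chain from a double-bonded chain carbon. Among the compounds with values here, the one measured step that bears on this is an at least 3.3-fold higher number from compound 1 to compound 3 (0.52 log units; beyond the scatter), in which a group carrying a hydrogen-bond donor entered the chain. The 8-acetamidooctyl group of compound 4 likewise carries 1 hydrogen-bond donor, so a rise beyond the scatter is expected in this assay, possibly reaching the limit. Compound 4 is therefore expected to give about 8 ug/mL, between 3 ug/mL and 20 ug/mL. That amounts to an expected step of a 2.7-fold higher number from compound 1 to compound 4 (0.43 log units; beyond the scatter).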

Compound 4, concentration for 50% growth inhibition: > 10 ug/mL
Compound 4: only a limit was reported; the forecaster's own chance of this, stated with the estimate: 35%; middle value at least 1.2-fold (0.09 log units) away from the limit.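

In this assay compound 4 gives > 10 ug/mL, which is a limit of the assay and not a number. The change of pentyloxy to 8-acetamidooctyl on a saturated chain carbon, seven bonds along the chain from a double-bonded chain carbon, amounts to an at least 3.3-fold higher number from compound 1 to compound 4 (0.52 log units; beyond the scatter), so the loss of growth inhibition first seen with the hydroxyl of compound 3 also appears with the amide hydrogen of a different, larger group. Among the compounds shown, both chains carrying a hydrogen-bond donor now end at the same limit, while the two without one do not: the limit of > 10 ug/mL in this assay, at which 2 of the 4 values shown sit.

As far as these compounds go, how far compound 3 and compound 4 lie past that limit stays open, so no order between them can be given. Also open, from the compounds shown here alone, is whether a plain octyl group, an amine or a carboxylic acid in place of the 8-acetamidooctyl group would reach the limit too.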